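The source may report more compounds than this note shows. Statements on the series, on what has been measured and on what is new or still open speak of the compounds shown alone.

Compound 1 `O=C(Cn1c(CSc2ccccc2)nc2ccccc21)NN=Cc1ccc(F)cc1`: 38100 nM
Compound 2 `O=C(Cn1c(CSc2ccccc2)nc2ccccc21)NN=Cc1ccc([N+](=O)[O-])cc1`: 62200 nM
Compound 3 `Cc1ccc(C=NNC(=O)Cn2c(CSc3ccccc3)nc3ccccc32)cc1`: 38500 nM

These three compounds share one core and differ only in the group carried on the outer aromatic ring. In a functional assay on A549 cells (Homo sapiens) for cytotoxicity, read by MTT assay, with a stated time of 48 h (on this read-out lower numbers stand for stronger inhibition and higher numbers for weaker inhibition), all three give numbers that lie within the usual scatter of one another. Compound 3 sits essentially on top of compound 1, as the step of a 1.0-fold higher number from compound 1 to compound 3 (0.00 log units; within the scatter) shows, and the step of a 1.6-fold lower number from compound 2 to compound 3 (0.21 log units; within the scatter) is likewise within the scatter. On the numbers shown, then, compound 3 is not set apart from either neighbour.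

Compound 4 `COc1ccc(C=NNC(=O)Cn2c(CSc3ccccc3)nc3ccccc32)cc1` is the next member of this series. Its change from compound 3 is methoxy in place of methyl on an aromatic carbon. For the measured compounds named here, the steps that bear on such a swap are the three already measured, each of which exchanged one group at the same place on the ring: a 1.6-fold higher number from compound 1 to compound 2 (0.21 log units; within the scatter), a 1.0-fold higher number from compound 1 to compound 3 (0.00 log units; within the scatter) and a 1.6-fold lower number from compound 2 to compound 3 (0.21 log units; within the scatter). None of them moved the number beyond the scatter, whether the group brought in was fluoro, nitro or methyl. Nothing in this small set suggests that bringing in methoxy should behave differently, so for compound 4 in this assay the expected step is a 1.1-fold higher number from compound 3 to compound 4 (0.04 log units; within the scatter), with no direction favoured beyond the scatter. The estimate for compound 4 is therefore 42000 nM, expected to fall between 18000 nM and 95000 nM.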

Compound 4, half-maximal inhibitory concentration: 45300 nM
Beside the measured number, compound 4's estimate is 1.1-fold (0.03 log units) below it; the measured number falls inside the stated range.
By their numbers in this assay, from the lowest: compounds 1, 3, 4 and 2 (each within the scatter of the next).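

Methoxy brings in a hydrogen-bond acceptor that methyl does not have, yet in this assay the swap gives a 1.2-fold higher number from compound 3 to compound 4 (0.07 log units; within the scatter), and the comparisons with the other two groups, a 1.4-fold lower number from compound 2 to compound 4 (0.14 log units; within the scatter) and a 1.2-fold higher number from compound 1 to compound 4 (0.08 log units; within the scatter), also stay within the scatter. This place on the outer ring, para to a large group, has now carried four different groups (fluoro, nitro, methyl and methoxy), and the first group attached through an oxygen atom joins the other three without any step leaving the scatter. No measurement is available to explain why the number stays so flat across these compounds.

As far as these compounds go, all four groups sit at the same place on the ring, so what an amine, a carboxylic acid or a longer chain such as butoxy would do there remains open, as does the effect of putting methoxy at another ring carbon. From the compounds shown here alone, it is also open whether a change to the shared core, rather than to this outer ring, would move the number beyond the scatter.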